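Adding a Butyl Chain to the Aromatic Ring of Compound 1

This account rests on a few compounds, and the source may have more. Where it says the series, first, only, none or still open, it means among the compounds named here.

The measured compounds:
compound 1, `O=C(O)CSC(CC(=O)c1ccccc1)C(=O)O`, 15000 nM
compound 2, `Cc1ccc(C(=O)CC(SCC(=O)O)C(=O)O)c(C)c1`, 3830 nM
compound 3, `Cc1ccc(C)c(C(=O)CC(SCC(=O)O)C(=O)O)c1`, 2680 nM

In a functional assay on HeLa cells (Homo sapiens) (a higher number here means a weaker inhibitor, a lower number a stronger inhibitor), compound 1 gives 15000 nM, the highest of the three numbers. Compound 2, which carries two methyl groups on its aromatic ring, gives 3830 nM in this assay, and compound 3, also with two methyl groups, gives 2680 nM. Both of these lie well below the number for compound 1, further than the usual scatter would account for, so the unsubstituted ring of compound 1 goes with the weakest inhibition among the three.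

Compound 4, `CCCCc1ccc(C(=O)CC(SCC(=O)O)C(=O)O)cc1`, has not yet been measured in this assay. It differs from compound 1 in one place: butyl in place of hydrogen on an aromatic carbon. Among the measured compounds shown here, no step between two measured compounds matches this change exactly, but the two ring-substituted compounds 2 and 3 both sit below compound 1, which makes a lower number for compound 4 the expected direction. The step from compound 1 to compound 4 is expected to be a 6.0-fold lower number from compound 1 to compound 4 (0.78 log units; beyond the scatter), beyond the scatter. On that basis compound 4 is estimated at 2500 nM, within a range of 700 nM to 9000 nM.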

Compound 4, half-maximal inhibitory concentration: 1910 nM
Beside the measured number, compound 4's estimate is 1.3-fold (0.12 log units) above it; low and high end bracket the measured number.
By their numbers in this assay, from the lowest: compounds 4, 3 and 2 (each within the scatter of the next); then compound 1.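

In this assay, among the compounds shown here, butyl in place of hydrogen on an aromatic carbon, para to a large group, gives a 7.9-fold lower number from compound 1 to compound 4 (0.90 log units; beyond the scatter), and this is the first step in the set in which only one place changes. Compounds 2 and 3 each carry two methyl groups, so they could not show what a single group at one position does; this step shows that one butyl chain at this position is enough to move the number beyond the scatter. No measurement shown accounts for this change.

As far as these compounds go, whether a longer chain at the same position would lower the number further remains open. So does whether an amine or a carboxylic acid there would give a number like that of compound 4, since only butyl has been seen at this place.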